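A few compounds are considered here, and "the series" means these few. Any claim that something is new, unique, unknown or untested is made for them only; others in the source may bear on it.

Compound 1 `CN(C[C@H]1Cc2c(cccc2N2CCN(C3COC3)CC2)CN1)[C@H]1CCCc2cccnc21` was tested in a functional assay on CCRF-CEM cells for agonist activity at C-X-C chemokine receptor type 4 (Homo sapiens), read by calcium flux, with a stated time of 25 min; a lower number here means that less compound is needed, a higher number that more compound is needed for the effect. In this assay compound 1 gives > 30000 nM, which is a limit of the assay rather than a number. Two close relatives share its core and differ only in the group on the aromatic carbon. Compound 2 `C[C@@H]1CN(c2cccc3c2C[C@H](CN(C)[C@H]2CCCc4cccnc42)NC3)C[C@H](C)N1` gives > 30000 nM, again a limit. Compound 3 `CN(C[C@H]1Cc2c(cccc2N2CCN3CCC[C@@H]3C2)CN1)[C@H]1CCCc2cccnc21` gives > 30000 nM, also a limit. The steps among these three, a step that the two limits leave unreadable from compound 1 to compound 2, a step that the two limits leave unreadable from compound 1 to compound 3 and a step that the two limits leave unreadable from compound 2 to compound 3, cannot be read because of the limit of > 30000 nM in this assay, at which 3 of the 3 values shown sit. Compound 4 `CN(C[C@H]1Cc2c(cccc2N2CCN(c3cccc(C(F)(F)F)c3)CC2)CN1)[C@H]1CCCc2cccnc21` has not yet been measured. It differs from compound 1 by 3-(trifluoromethyl)phenyl in place of oxetan-3-yl on an amine nitrogen in a ring. Going by the values given here, all three measured steps change the group on the aromatic carbon as a whole, and none of them yields a readable size, so there is no measured step to lean on for this change. Compound 1 starts from a limit, so any movement in either direction begins at an unknown point. The expectation for compound 4 in this assay is therefore cautious: compound 4 is estimated at 30000 nM, with a range from 3000 nM to 100000 nM. The step this estimate means, a number no higher from compound 1 to compound 4 (the limit leaves the size open), is expected rather than measured, and a further limit remains the likeliest outcome.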

Compound 4, half-maximal effective concentration: > 30000 nM
Compound 4: a limit, no number (the forecaster's own chance of this, stated with the estimate: 65%); the middle value sits exactly at the limit.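

Compound 4, like compound 1, gives a limit of the assay and not a number, so the step from one to the other cannot be read: the limit of > 30000 nM in this assay, at which 4 of the 4 values shown sit.

The compounds shown leave open what concentration each one needs for the effect in this assay, and whether 3-(trifluoromethyl)phenyl in place of oxetan-3-yl changes it at all.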